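Extending a Chalcone Amide Series: Tolerability of Compound 4

This account rests on a few compounds, and the source may have more. Where it says the series, first, only, none or still open, it means among the compounds named here.

Compound 1 `COC(=O)c1cc(-c2cccc(NC(=O)c3ccc(OCc4ccc(Cl)cc4)cc3)c2)on1`, compound 2 `COC(=O)c1cc(-c2cccc(NC(=O)c3ccc(/C=C/C(=O)c4ccccc4)cc3)c2)on1` and compound 3 `COC(=O)c1cc(-c2cccc(NC(=O)c3ccc(/C=C/C(=O)c4cc(F)ccc4F)cc3)c2)on1` share one core and differ only in the group attached to the far end of the amide. All three were tested in an ADME assay on Vero cells (Chlorocebus sabaeus) for cytotoxicity, read by MTT assay, with a stated time of 72 h; a higher number here means that more compound is tolerated, a lower number that less compound is tolerated. In this assay compound 1 gives > 80 ug/mL, which is a limit of the assay rather than a number. Compound 2 gives > 50 ug/mL, again a limit. Compound 3 gives > 40 ug/mL, also a limit. The three readings sit at the limit of > 80 ug/mL in this assay, at which 1 of the 3 values shown sits, the limit of > 50 ug/mL in this assay, at which 1 of the 3 values shown sits, and (the limit of > 40 ug/mL in this assay, at which 1 of the 3 values shown sits), so the steps a step that the two limits leave unreadable from compound 1 to compound 2, a step that the two limits leave unreadable from compound 1 to compound 3 and a step that the two limits leave unreadable from compound 2 to compound 3 cannot be sized. Compound 3 thus stands only at a limit, as do the two other values shown.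

Compound 4 `CCCOc1ccc(C(=O)/C=C/c2ccc(C(=O)Nc3cccc(-c4cc(C(=O)OC)no4)c3)cc2)cc1` is the next member. Its change from compound 3 is 4-propoxyphenyl in place of 2,5-difluorophenyl on a carbonyl carbon. Going by the values given here, none of the measured steps gives a readable size for such a change, so no shift beyond the scatter can be predicted in this assay. Compound 4 is therefore expected to be tolerated to a similar degree, with an estimated step that the limit leaves unreadable from compound 3 to compound 4. The estimate for compound 4 in this assay is 60 ug/mL, with a range from 30 ug/mL to 120 ug/mL.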

Compound 4, half-maximal cytotoxic concentration: > 40 ug/mL
Compound 4: no number, only a limit (the forecaster's own chance of this, stated with the estimate: 70%); the middle value is on the limit's open side.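

In this assay compound 4 gives > 40 ug/mL, which is a limit of the assay and not a number. Going by these compounds alone, compound 2 and compound 3 also stand only at limits, and no step from either of them to compound 4 can be read. The compounds shown leave open whether changing the group on the carbonyl carbon shifts tolerance in this assay at all.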